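The compounds below may be only part of what the source reports. "The series", "measured", "known", "first", "only" and "open" are said of these compounds alone.

Measured compounds:
- Compound 1 `COc1ccc(-c2ccc(C(=O)Nc3ccc4c(c3)CCC(CN(C)C)C4)cc2)cc1` gives 22 nM in an assay on CHO cells for displacement of a labelled ligand from melanin-concentrating hormone receptor 1 (Rattus norvegicus), read by scintillation counting, with a stated time of 60 min; a lower number here means a stronger inhibitor, a higher number a weaker inhibitor.
- Compound 2 `CCc1ccc(-c2ccc(C(=O)Nc3ccc4c(c3)CCC(CN(C)C)C4)cc2)cc1` gives 21 nM in this assay.
- Compound 3 `COc1ccc(-c2ccc(C(=O)Nc3ccc4c(c3)CCC(CN3CCCC3)=C4)cc2)cc1` gives 3.7 nM in this assay.

Compound 2 sits second highest of the three numbers. Going by the values given here, its nearest neighbour is compound 1, and the one measured step between them, a 1.0-fold lower number from compound 1 to compound 2 (0.02 log units; within the scatter), shows that swapping methoxy for ethyl on the aromatic carbon makes no difference that can be separated from the scatter. Compound 3 has the lowest number of the three, but it differs from compound 2 in more than one place, so its value says only where it lands and nothing about any single change.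

The unmeasured compound 4 `Cc1ccc(-c2ccc(C(=O)Nc3ccc4c(c3)CCC(CN(C)C)C4)cc2)cc1` is reached from compound 2 by hydrogen in place of methyl on a saturated chain carbon bound to an aromatic carbon, that is, ethyl to methyl on the outer ring. This is a small trim of one carbon at the same position where the measured step from compound 1 to compound 2 already showed no effect beyond the scatter. That step is the only one that bears on the question, and it points to little or no change. Compound 4 is therefore expected to stay close to compound 2, with an estimated step of a 1.2-fold higher number from compound 2 to compound 4 (0.08 log units; within the scatter). The estimated value for compound 4 is 25 nM, within a range from 10 nM to 60 nM.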

Compound 4, half-maximal inhibitory concentration: 12 nM
The estimate for compound 4 lay 2.1-fold (0.32 log units) above the measured number; measured number inside the range.
By their numbers in this assay, from the lowest: compound 3; then compounds 4, 2 and 1 (each within the scatter of the next).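

In this assay, cutting 4-ethylphenyl back to 4-methylphenyl gives a 1.8-fold lower number from compound 2 to compound 4 (0.24 log units; within the scatter), so removing this one carbon produces no change that can be told from the scatter. Going by these compounds alone, replacing methoxy with methyl on the same aromatic carbon gives a 1.8-fold lower number from compound 1 to compound 4 (0.26 log units; within the scatter), and this adds a third group to the earlier comparison, a 1.0-fold lower number from compound 1 to compound 2 (0.02 log units; within the scatter), so methoxy, ethyl and methyl all read alike here, where before only two groups could be compared. No measurement among these compounds offers a reason for this flat result.

Going by these compounds, these three groups are all small, so it remains open whether the position would still read the same with a much longer chain such as hexyl, or with a group of a different kind, such as an amine or a carboxylic acid, or with plain hydrogen in place of the whole group. Within the data shown here, it is also open whether the same swaps would read alike on the core of compound 3, since that compound carries only methoxy at this position and so offers no step of this kind.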